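A few compounds are considered here, and "the series" means these few. Any claim that something is new, unique, unknown or untested is made for them only; others in the source may bear on it.

Measured in a toxicity assay on NIH3T3 cells (Mus musculus) for cytotoxicity, read by resazurin assay; a higher number here means that more compound is needed for the effect, a lower number that less compound is needed:
Compound 1 `CC(=O)c1ccc(NCc2cncn2Cc2ccc(-c3ccccc3)cc2)cc1-c1ccccc1`: > 10000 nM, a limit.
Compound 2 `c1ccc(-c2ccc(Cn3cncc3CNc3ccc(-c4nc5ccccc5s4)c(-c4ccccc4)c3)cc2)cc1`: > 1000 nM, a limit.
Compound 3 `CCCC(=O)c1ccc(NCc2cncn2Cc2ccc(-c3ccccc3)cc2)cc1-c1ccccc1`: > 10000 nM, a limit.

Compound 2 has no numerical value and stands at the limit of > 1000 nM in this assay, at which 1 of the 3 values shown sits. The other two measured compounds stand at the limit of > 10000 nM in this assay, at which 2 of the 3 values shown sit, so the series offers no number to work from.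

Compound 4 `Cc1cccc(-c2cc(NCc3cncn3Cc3ccc(-c4ccccc4)cc3)ccc2-c2nc3ccccc3s2)c1C` differs from compound 2 by one change: 2,3-dimethylphenyl in place of phenyl on an aromatic carbon. The group that changes lies ortho to a 1,3-benzothiazol-2-yl group.

Three measured steps are available: a step that the two limits leave unreadable from compound 1 to compound 2, a step that the two limits leave unreadable from compound 1 to compound 3 and a step that the two limits leave unreadable from compound 2 to compound 3. None has a readable size, and none involves the phenyl that changes here. They therefore set neither a size nor a direction for this change, and no step beyond the scatter is expected in this assay. The expected step is a step that the limit leaves unreadable from compound 2 to compound 4. Compound 4 is estimated at 5000 nM, with an expected range from 1500 nM to 15000 nM, and a report as a limit alone would be no surprise.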

Compound 4, half-maximal effective concentration: > 1000 nM
Compound 4 gave a limit, no number; the forecaster's own chance of this, stated with the estimate: 70%; the middle value is on the limit's open side.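

In this assay compound 4 gives > 1000 nM, a limit. Compound 2 gives > 1000 nM, also a limit. No step can be read between compound 2 and compound 4. The compounds shown leave open at what concentration any of them reaches the half-maximal effect in this assay.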